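The source may hold more compounds than are shown below. What is called first, only, known or untested is meant among the compounds shown, and "the series" means these compounds.

Values in a physicochemical assay for solubility, measured as thermodynamic solubility, with a stated time of 24 h, at pH 6.8 (a higher number here means a more soluble compound, a lower number a less soluble compound), follow.

- compound 1 (`Cc1cc(C)c2cc(C(=O)NC(C)C)[nH]c2c1`): 20000 nM
- compound 2 (`Cc1cc(C)c2cc(C(=O)NC3CCCCCC3)[nH]c2c1`): < 4000 nM (a limit, not a number)
- compound 3 (`Cc1cc(C)c2cc(C(=O)N[C@@H]3CCCC[C@@H]3C)[nH]c2c1`): not yet measured

Compound 2 has no number, only (the limit of < 4000 nM in this assay, at which 1 of the 2 values shown sits). The change to compound 3 is 2-methylcyclohexyl in place of cycloheptyl on an amide-type nitrogen, the same atoms joined differently. Going by the values given here, the only measured step, an at least 5.0-fold lower number from compound 1 to compound 2 (0.69 log units; beyond the scatter), came with cycloheptyl in place of isopropyl on an amide-type nitrogen, a different exchange, so it bears only loosely here. No step beyond the scatter is expected in this assay. The estimated step is a step that the limit leaves unreadable from compound 2 to compound 3. For compound 3 the expected value is 3000 nM, with an estimated range from 1000 nM to 8000 nM.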

Compound 3, solubility: < 4000 nM
Compound 3: a limit, no number (the forecaster's own chance of this, stated with the estimate: 65%); the middle value is on the limit's open side.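

In this assay, 2-methylcyclohexyl in place of isopropyl on the amide-type nitrogen gives an at least 5.0-fold lower number from compound 1 to compound 3 (0.69 log units; beyond the scatter). The lower number seen with cycloheptyl therefore recurs with a second carbon-only ring of 7 heavy atoms, here a six-membered one carrying 2 defined stereocentres. Cycloheptyl and 2-methylcyclohexyl cannot be ranked against each other, because compound 2 and compound 3 both stop at a limit: the limit of < 4000 nM in this assay, at which 2 of the 3 values shown sit.

Open, from the compounds shown here alone, is the true value of each of these two compounds in this assay. Also open, going by these compounds, is whether a cyclohexyl ring carrying an amine or a carboxylic acid on the amide-type nitrogen would return to the level of compound 1.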